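Branching the ketone chain in a glutamate receptor modulator series

The source may hold more compounds than are shown below. What is called first, only, known or untested is meant among the compounds shown, and "the series" means these compounds.

Compound 2 `CCC(=O)c1ccc(OCCCCOc2ccc(F)c(C(=O)O)c2)c(C)c1O` carries a propanoyl group on the shared core. For the measured compounds named here, in an assay on HEK293 cells for positive allosteric modulation of metabotropic glutamate receptor 2 (Rattus norvegicus), read by thallium flux, with a stated time of 2.5 min (a lower number here means that less compound is needed, a higher number that more compound is needed for the effect), compound 2 gives 124 nM, the lowest of the two numbers available so far, though its only neighbour sits within the scatter of it. That neighbour, compound 1 `Cc1c(OCCCCOc2ccc(F)c(C(=O)O)c2)ccc(C(=O)CC(C)(C)C)c1O`, gives 208 nM in this assay. Going by the values given here, the single measured step, a 1.7-fold lower number from compound 1 to compound 2 (0.22 log units; within the scatter), replaced a tert-butyl with a methyl on the saturated chain carbon bound to the carbonyl carbon and did not move the number beyond the scatter. Compound 3 `Cc1c(OCCCCOc2ccc(F)c(C(=O)O)c2)ccc(C(=O)C(C)C)c1O` has not yet been measured in this assay; it differs from compound 2 by methyl in place of hydrogen on a saturated chain carbon bound to a carbonyl carbon and a saturated chain carbon. Among the compounds with values here, since the one step that altered the same carbon was within the scatter, compound 3 is expected to show no step beyond the scatter, a 1.2-fold higher number from compound 2 to compound 3 (0.08 log units; within the scatter). Compound 3 is therefore estimated at 150 nM in this assay, with a range from 65 nM to 350 nM.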

Compound 3, half-maximal effective concentration: 171 nM
Estimate against measurement, compound 3: 1.1-fold (0.06 log units) below, and the stated range covers the measured number.
By their numbers in this assay, from the lowest: compounds 2, 3 and 1 (each within the scatter of the next).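

In this assay, a methyl on the saturated chain carbon bound to the carbonyl carbon, turning ethyl into isopropyl, gives a 1.4-fold higher number from compound 2 to compound 3 (0.14 log units; within the scatter), so a branch placed on this carbon itself is tolerated, which the earlier step involving tert-butyl could not show. Isopropyl in place of neopentyl on the carbonyl carbon gives a 1.2-fold lower number from compound 1 to compound 3 (0.09 log units; within the scatter), so propanoyl, isopropylcarbonyl and the neopentyl ketone of compound 1 all lie within the scatter of one another, and no size of chain among these three separates them. No supporting evidence bears on why this position absorbs these changes.

The compounds shown leave open whether a cyclopropyl ring, a phenyl ring or an amine on the carbonyl carbon would give a step beyond the scatter. They also leave open whether a longer chain would do so.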